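Methoxy for Bromo on the Aryl Amide Terminus

The source may report more compounds than this note shows. Statements on the series, on what has been measured and on what is new or still open speak of the compounds shown alone.

Measured compounds:
compound 1, `Cc1nc(N)sc1CCCN/C(N)=N/C(=O)NC(C)c1ccc(Br)cc1`: 55 nM
compound 2, `Cc1nc(N)sc1CCCN/C(N)=N/C(=S)N[C@H](C)c1ccccc1`: 89.1 nM
compound 3, `Cc1nc(N)sc1CCCN/C(N)=N/C(=O)N[C@@H](C)c1ccccc1`: 23.4 nM

All three numbers come from a functional assay on Right cardiac atrium for agonist activity at histamine H2 receptor (Cavia porcellus), with a stated time of 30 min, in the presence of a further agent that is not named here; on this read-out higher numbers stand for an effect only at larger amounts of compound and lower numbers for an effect already at smaller amounts. Among them compound 1 gives 55 nM, the second highest of the three. Its nearest neighbour is compound 2, whose 89.1 nM lies within the scatter of repeated measurements, so no order between compound 1 and compound 2 can be read. Compound 3 gives 23.4 nM, a lower number that lies beyond the scatter, so compound 3 acts at smaller amounts than compound 1.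

Compound 4, `COc1ccc(C(C)NC(=O)/N=C(\N)NCCCc2sc(N)nc2C)cc1`, has not yet been measured. It differs from compound 1 in a single place: methoxy in place of bromo on an aromatic carbon. Going by the values given here, no step between two measured compounds isolates this exchange, so the expectation rests on the spread of the three numbers alone. A step of modest size is expected from compound 1 to compound 4 in this assay, most likely not beyond the scatter in either direction, as a 1.1-fold lower number from compound 1 to compound 4 (0.04 log units; within the scatter). Compound 4 is therefore estimated at 50 nM, with a range from 15 nM to 160 nM.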

Compound 4, half-maximal effective concentration: 38 nM
The estimate for compound 4 lay 1.3-fold (0.12 log units) above the measured number; the range from low to high includes it.
By their numbers in this assay, from the lowest: compounds 3, 4, 1 and 2 (each within the scatter of the next, the first and the last beyond it).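

The exchange of 4-bromophenyl to 4-methoxyphenyl is the only step among these compounds that isolates this position, and in this assay it reads as a 1.4-fold lower number from compound 1 to compound 4 (0.16 log units; within the scatter), so no order between the two compounds can be read. On this read-out, the position therefore takes either group without a change that stands out from the scatter, even though the two groups differ in heavy atoms and in hydrogen-bond acceptors. Nothing measured here gives a reason for this result.

From the compounds shown here alone, whether an amine or a carboxylic acid on the same aromatic carbon would also leave the number within the scatter remains open. Going by these compounds, compound 1 and compound 4 are drawn without stated stereochemistry, so how each mirror form responds to the exchange also stays open.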